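Series notes: amide-linked purine acids, switching the side chain

A few compounds are considered here, and "the series" means these few. Any claim that something is new, unique, unknown or untested is made for them only; others in the source may bear on it.

Measured so far in a functional assay on the whole organism (Tail, strain ICR) with Mus musculus as the target, in the tail flick test, with a stated time of 90 min, at a dose of 25 umol/kg by the oral route; a higher number here means a stronger effect of the compound at the dose given, a lower number a weaker effect:
compound 1 `CC[C@H](C)[C@H](NC(=O)CN(c1nc(Cl)nc2[nH]cnc12)C1CC1)C(=O)O` gives 27.4%
compound 2 `CC[C@H](C)[C@H](NC(=O)CN(c1nc(Cl)nc2[nH]cnc12)C1CC1)C(=O)OCc1ccccc1` gives 36.3%
compound 3 `C[C@H](NC(=O)CN(c1ncnc2c1ncn2C1CCCCO1)C1CC1)C(=O)OCc1ccccc1` gives 32.1%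

Compound 1 sits at the low end of the three numbers, yet the gaps to the other two are within the scatter: the nearest is compound 3, the furthest compound 2. Among the measured compounds shown here, the one step between compounds that differ in a single place is a number 8.9 percentage points higher from compound 1 to compound 2 (within the scatter), also within the scatter, and it concerns the oxygen of the acid, not the side chain.

Compound 4 `O=C(O)C[C@H](NC(=O)CN(c1nc(Cl)nc2[nH]cnc12)C1CC1)C(=O)O` differs from compound 1 at the saturated chain carbon bound to an amide-type nitrogen and a carbonyl carbon: carboxymethyl in place of sec-butyl on a saturated chain carbon bound to an amide-type nitrogen and a carbonyl carbon. For the measured compounds named here, no measured pair changes this place, so the step to compound 4 has no direct precedent in this assay. Compounds 2 and 3 carry different side chains, but they also differ from compound 1 in the acid and in the core, so their values show only that a changed side chain together with those other changes gave numbers within the scatter of compound 1.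

With nothing pointing to a move beyond the scatter, compound 4 is expected to stay close to compound 1, giving a step of a number 2.4 percentage points lower from compound 1 to compound 4 (within the scatter). Compound 4 is therefore estimated at 25%, in the range 12% to 40%.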

Compound 4, a percentage reported as activity, at one dose (the size of the read-out at that dose, not a potency): 25.1%
Compound 4: the middle estimate sits 0.1 percentage points below what was measured; measured number inside the range.
By their numbers in this assay, from the lowest: compounds 4, 1, 3 and 2 (each within the scatter of the next, the first and the last beyond it).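

This place now has a direct reading in this assay: carboxymethyl in place of sec-butyl on a saturated chain carbon bound to an amide-type nitrogen and a carbonyl carbon gives a number 2.3 percentage points lower from compound 1 to compound 4 (within the scatter). With the shared core and the free acid held fixed, an all-carbon side chain and one carrying oxygen are therefore not separated by this read-out, at this single dose and time, and the defined stereocentre of the sec-butyl group leaves without a step beyond the scatter. No measurement bearing on this result accompanies the compounds, so the step stands without an explanation.

A single exchange at this place says nothing about a side chain carrying an amine, such as aminobutyl, or about a longer chain or a phenyl ring there, any of which might or might not give a step beyond the scatter. As far as these compounds go, it also remains open whether benzyl on the acid oxygens of compound 4 would behave as it does in a number 8.9 percentage points higher from compound 1 to compound 2 (within the scatter), since that step comes from the sec-butyl side chain alone.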